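Cyclohexyl for 4-cyanobutyl on an aromatic nitrogen

The source may report more compounds than this note shows. Statements on the series, on what has been measured and on what is new or still open speak of the compounds shown alone.

Compound 1 `CN1C(=S)[C@@H](NC(=O)c2nc(Cc3ccccc3)n(C)n2)COc2ccccc21` gives 2.5 nM
Compound 2 `CCCn1nc(C(=O)N[C@H]2COc3ccccc3N(C)C2=S)nc1Cc1ccccc1` gives 288 nM
Compound 3 `CN1C(=S)[C@@H](NC(=O)c2nc(Cc3ccccc3)n(CCCCC#N)n2)COc2ccccc21` gives 2680 nM

In a functional assay on HT-29 cells (Homo sapiens) for inhibition, read by luminescence and CellTiter-Glo, with a stated time of 24 h (a higher number here means that more compound is needed for the effect, a lower number that less compound is needed), compound 3 has the highest number of the three. Going by the values given here, compound 4 `CN1C(=S)[C@@H](NC(=O)c2nc(Cc3ccccc3)n(C3CCCCC3)n2)COc2ccccc21` carries cyclohexyl in place of 4-cyanobutyl on an aromatic nitrogen and no measured compound has a ring there. The measured steps at this nitrogen are a 120-fold higher number from compound 1 to compound 2 (2.06 log units; beyond the scatter) and a 1100-fold higher number from compound 1 to compound 3 (3.03 log units; beyond the scatter) (both large) and a 9.3-fold higher number from compound 2 to compound 3 (0.97 log units; beyond the scatter) (modest). Compound 1 alone sits far lower, so a modest step to a lower number is expected in this assay with no return towards compound 1. The expected change is a 2.7-fold lower number from compound 3 to compound 4 (0.43 log units; beyond the scatter) in size. Compound 4 is estimated at 1000 nM with an expected range of 120 nM to 8000 nM in this wide estimate.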

Compound 4, half-maximal effective concentration: 4000 nM
Compound 4: middle estimate off by 4.0-fold (0.60 log units), on the low side; the range from low to high includes it.
By their numbers in this assay, from the lowest: compound 1; then compound 2; then compounds 3 and 4 (each within the scatter of the next).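

In this assay the step to a ring at this aromatic nitrogen is a 1.5-fold higher number from compound 3 to compound 4 (0.17 log units; within the scatter) and so does not separate cyclohexyl from 4-cyanobutyl, though one is a ring of carbon only and the other an open chain with a triple bond. The same ring stands at a 14-fold higher number from compound 2 to compound 4 (1.14 log units; beyond the scatter) and at a 1600-fold higher number from compound 1 to compound 4 (3.20 log units; beyond the scatter) on the same side as the chains, so it brings no return towards compound 1, and among these four compounds the low number stays with methyl alone. No measurement here explains this.

Going by these compounds, whether an amine, a carboxylic acid or a smaller ring such as cyclopropyl on this nitrogen would come closer to compound 1 stays open.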